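The source may report more compounds than this note shows. Statements on the series, on what has been measured and on what is new or still open speak of the compounds shown alone.

Working notes on the series. Compound 1 `COc1ccc(-c2cs/c(=N\NC(=O)c3ccc(O)cc3)n2-c2ccc(OC)cc2OC)cc1`, compound 2 `O=C(N/N=c1\scc(-c2ccc(Cl)cc2)n1-c1ccc(Cl)cc1Cl)c1ccc(O)cc1` and compound 3 `Cc1ccc(-c2cs/c(=N\NC(=O)c3ccc(O)cc3)n2-c2c(C)cccc2C)cc1` share a common core and have been run in a functional assay on CAKI-1 cells (Homo sapiens) for cytotoxicity, read by sulforhodamine B assay, with a stated time of 48 h; on this read-out higher numbers stand for lower toxicity in this test and lower numbers for higher toxicity in this test. In this assay compound 1 returns only a limit, < 100000 nM. For compound 2 the read-out is likewise a limit, < 100000 nM. Compound 3 also gives a limit, < 100000 nM. Among the compounds with values here, compound 2 therefore stands nowhere distinguishable among the three: the whole set sits at the limit of < 100000 nM in this assay, at which 3 of the 3 values shown sit, so no step between measured compounds can be sized and no direction can be read from them.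

Compound 4 `COc1ccc(-n2c(-c3ccc(Cl)cc3)cs/c2=N\NC(=O)c2ccc(O)cc2)c(OC)c1` is not yet measured. It differs from compound 2 in 2,4-dimethoxyphenyl in place of 2,4-dichlorophenyl on an aromatic nitrogen, in words 2,4-dimethoxyphenyl in place of 2,4-dichlorophenyl on an aromatic nitrogen. With every recorded value a limit, the measured compounds give no ground for a directional expectation. For compound 4 the expected step is a step that the limit leaves unreadable from compound 2 to compound 4, which is not expected to exceed the scatter. Compound 4 is expected to land in this assay at 30000 nM, between 5000 nM and 100000 nM, and most probably to be reported again as a limit.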

Compound 4, concentration lethal to 50% of the cells: < 100000 nM
Compound 4 was reported as a limit (the forecaster's own chance of this, stated with the estimate: 70%); the middle value lies beyond the limit too.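

Neither step, from compound 2 to compound 4 or from compound 1 to compound 4, can be read, because each value is a limit: the limit of < 100000 nM in this assay, at which 4 of the 4 values shown sit.
The compounds shown leave open how far below that limit each lies, and whether 2,4-dimethoxyphenyl in place of 2,4-dichlorophenyl changes the read-out at all.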